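From Methoxy to Amino on the Shared Core

This account rests on a few compounds, and the source may have more. Where it says the series, first, only, none or still open, it means among the compounds named here.

Measured so far in a functional assay on THP-1 cells (Homo sapiens) for inhibition, with a stated time of 48 h, tested at 50 uM; on this read-out lower numbers stand for less inhibition of growth and higher numbers for more inhibition of growth at the one concentration tested
Compound 1 `COc1ccc(/C=C/[C@@](C)(/C=C/c2ccc(O)cc2)CCC=C(C)C)cc1` gives 52%
Compound 2 `COc1ccc(/C=C/[C@@](C)(/C=C/c2ccc(O)cc2)CCC=C(C)C)cc1C=O` gives 45%

Among the measured compounds shown here, compound 1 has only one measured neighbour, and the single step between them is a number 7 percentage points lower from compound 1 to compound 2 (within the scatter). The two compounds therefore cannot be ranked apart.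

Compound 3 `CC(C)=CCC[C@@](C)(/C=C/c1ccc(N)cc1)/C=C/c1ccc(O)cc1` has not yet been measured. It differs from the core of compound 1 in one place (amino in place of methoxy on an aromatic carbon), with amino in place of methoxy on an aromatic carbon, so that 4-methoxyphenyl becomes 4-aminophenyl.

For the measured compounds named here, no measured step touches the methoxy group itself. Going by the values given here, the one step available, formyl in place of hydrogen on an aromatic carbon, is a different change and offers only indirect guidance. Resting on compound 2 with its 45%, no step beyond the scatter is expected in this assay, and the data support no direction. The estimated step is a number 2 percentage points lower from compound 1 to compound 3 (within the scatter). With so little evidence, the expected range is wide. Compound 3 is expected at 50%, with an estimated range of 32% to 68%.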

Compound 3, percent growth inhibition at one concentration: 51%
Compound 3: middle estimate off by 1 percentage points, on the low side, and the stated range covers the measured number.
By their numbers in this assay, from the lowest: compounds 2, 3 and 1 (each within the scatter of the next).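

In this assay, the exchange of 4-methoxyphenyl for 4-aminophenyl gives a number 1 percentage points lower from compound 1 to compound 3 (within the scatter), so the methoxy position, on an aromatic carbon para to a large group, now has a direct measurement rather than only the indirect guidance of the formyl step. Here a group with no hydrogen-bond donor gives way to one with a hydrogen-bond donor, and one heavy atom fewer is present at this place, yet the read-out does not separate compound 1 from compound 3 at the one concentration tested. Nothing available bears on the reason for this result.

The compounds shown leave open whether other groups at this position, such as a hydroxyl, a carboxylic acid, an acetamide or a longer alkoxy chain, would also stay within the scatter of compound 1. They also leave open whether compound 1 and compound 3 would still be indistinguishable at other concentrations, since a single concentration cannot show how growth inhibition changes with dose for either compound.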